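Compound 1 and the search for a stronger replacement

This account rests on a few compounds, and the source may have more. Where it says the series, first, only, none or still open, it means among the compounds named here.

Measured so far in a functional assay on MCF7 cells (Homo sapiens) for inhibition, read by MTT assay, with a stated time of 48 h; on this read-out lower numbers stand for stronger inhibition and higher numbers for weaker inhibition:
- compound 1 `CCOC(=O)C1=C(N/C=N/c2cccnc2Cl)Nc2[nH]nc(C)c2C1c1ccc(N(C)C)cc1` gives 4180 nM
- compound 2 `CCOC(=O)C1=C(N/N=C(\C#N)C(N)=O)Nc2[nH]nc(C)c2C1c1ccc(N(C)C)cc1` gives 50100 nM

Compound 1 has the lower of the two numbers and so the stronger inhibition. Compound 3 `CCOC(=O)C1=C(N/C=N/c2ncc(-c3ccccc3)s2)Nc2[nH]nc(C)c2C1c1ccc(N(C)C)cc1` carries 5-phenyl-1,3-thiazol-2-yl in place of 2-chloropyridin-3-yl on a double-bonded nitrogen. For the measured compounds named here, one measured step bears on this, and it is large and beyond the scatter (a 12-fold higher number from compound 1 to compound 2 (1.08 log units; beyond the scatter)). There, a group with no ring replaced a ring-bearing group. Compound 3 keeps an aromatic ring, so no step beyond the scatter is expected in this assay and no direction can be called. The expected change is small (a 1.0-fold lower number from compound 1 to compound 3 (0.02 log units; within the scatter)). Compound 3 is estimated at 4000 nM (range 1300 nM to 13000 nM).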

Compound 3, half-maximal inhibitory concentration: 10100 nM
Beside the measured number, compound 3's estimate is 2.5-fold (0.40 log units) below it; measured number inside the range.
By their numbers in this assay, from the lowest: compound 1; then compound 3; then compound 2.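

In this assay, 5-phenyl-1,3-thiazol-2-yl in place of 2-chloropyridin-3-yl gives a 2.4-fold higher number from compound 1 to compound 3 (0.38 log units; beyond the scatter) and weakens inhibition. Keeping an aromatic ring on this double-bonded nitrogen therefore does not hold the number level, and the exact ring group matters. No measurement here explains the shift. Going by these compounds, the ring type and the added phenyl changed together, so their separate contributions remain unknown. A plain 1,3-thiazol-2-yl group, without the phenyl, would help to pull these two changes apart.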